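A few compounds are considered here, and "the series" means these few. Any claim that something is new, unique, unknown or untested is made for them only; others in the source may bear on it.

Measured so far:
compound 1, `CCOCc1cc(CN2CCCCC2)c(O)c2ncccc12`, 776 nM;
compound 2, `CC(C)OCc1cc(CN2CCCCC2)c(O)c2ncccc12`, 479 nM;
compound 3, `CCOCc1cc(CN2CCC(C)CC2)c(O)c2ncccc12`, 468 nM.

All three values come from a functional assay on MES-SA/Dx5 cells (Homo sapiens) for inhibition, with a stated time of 72 h; a lower number here means a stronger inhibitor, a higher number a weaker inhibitor. Compound 1 and compound 2 differ by methyl in place of hydrogen on a saturated chain carbon bound to an oxygen on a saturated carbon and a saturated chain carbon, and the step is a 1.6-fold lower number from compound 1 to compound 2 (0.21 log units; within the scatter). Compound 1 and compound 3 differ by methyl in place of hydrogen on a saturated ring carbon, with the step of a 1.7-fold lower number from compound 1 to compound 3 (0.22 log units; within the scatter). Compound 2 and compound 3 sit within the scatter of each other, so no order between them is claimed.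

Compound 4, `CC1CCN(Cc2cc(COC(C)C)c3cccnc3c2O)CC1`, has not yet been run in this assay. It differs from compound 3 by methyl in place of hydrogen on a saturated chain carbon bound to an oxygen on a saturated carbon and a saturated chain carbon, which is the same change as between compound 1 and compound 2, at a place described in the same words. The two cores differ by methyl in place of hydrogen on a saturated ring carbon.

For compound 4 the step of a 1.4-fold lower number from compound 3 to compound 4 (0.15 log units; within the scatter) is expected, because a 1.6-fold lower number from compound 1 to compound 2 (0.21 log units; within the scatter) gave only a small move that stayed within the scatter, and the same change here is expected to do likewise. Compound 4 is therefore estimated at 330 nM in this assay, with a likely range from 170 nM to 650 nM.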

Compound 4, half-maximal inhibitory concentration: 355 nM
Estimate against measurement, compound 4: 1.1-fold (0.03 log units) below; low and high end bracket the measured number.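

In this assay, ethyl to isopropyl on the core carrying the methyl on a saturated ring carbon gives a 1.3-fold lower number from compound 3 to compound 4 (0.12 log units; within the scatter), and this agrees with the earlier step on the other core: the same change on two cores in this assay, a 1.6-fold lower number (0.21 log units; within the scatter) from compound 1 to compound 2 and a 1.3-fold lower number (0.12 log units; within the scatter) from compound 3 to compound 4, 1.2-fold (0.09 log units) apart, within the scatter of two such steps

Methyl in place of hydrogen on a saturated ring carbon, read with isopropoxymethyl in place, gives a 1.3-fold lower number from compound 2 to compound 4 (0.13 log units; within the scatter), and this also agrees with its earlier counterpart: the same change on two cores in this assay, a 1.7-fold lower number (0.22 log units; within the scatter) from compound 1 to compound 3 and a 1.3-fold lower number (0.13 log units; within the scatter) from compound 2 to compound 4, 1.2-fold (0.09 log units) apart, within the scatter of two such steps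

Each change therefore carries from one core to the other with no difference that can be told from the scatter, but since every step lies within the scatter, these four compounds do not show that either change moves the number at all, or that the two changes add.

The compounds shown leave open whether this holds for a longer chain in place of isopropyl, or for a carboxylic acid in place of the methyl on the saturated ring carbon. They also leave open whether a larger step, once beyond the scatter, would carry between cores in this assay.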